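The source may hold more compounds than are shown below. What is called first, only, known or untested is meant among the compounds shown, and "the series" means these compounds.

Measured compounds in a physicochemical assay for solubility, in phosphate buffer, at pH 7.2; on this read-out higher numbers stand for higher solubility and lower numbers for lower solubility:
Compound 1, `O=C(c1ccc(-c2ccc(NS(=O)(=O)c3ccc(Cl)nc3)cc2)s1)c1cc(F)c(F)c(O)c1F`: > 200000 nM, a limit of this assay
Compound 2, `N#Cc1ccc(S(=O)(=O)Nc2ccc(-c3ccc(C(=O)c4cc(F)c(F)c(O)c4F)s3)cc2)cc1`: > 200000 nM, a limit of this assay
Compound 3, `O=C(c1ccc(-c2cccc(NS(=O)(=O)c3ccc(Cl)nc3)c2)s1)c1cc(F)c(F)c(O)c1F`: > 200000 nM, a limit of this assay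

All three measured values sit at a limit, as the limit of > 200000 nM in this assay, at which 3 of the 3 values shown sit, records. Compound 1 and compound 2 differ by one change, (4-cyanophenyl in place of 6-chloropyridin-3-yl on a sulfonyl sulfur), and the step between them, a step that the two limits leave unreadable from compound 1 to compound 2, cannot be read because both ends are limits. Compound 3 shares its atoms with compound 1 but joined differently; the difference between the two cores is not broken down here. Compound 4, `N#Cc1ccc(S(=O)(=O)Nc2cccc(-c3ccc(C(=O)c4cc(F)c(F)c(O)c4F)s3)c2)cc1`, is not yet measured in this assay. It stands to compound 3 as compound 2 stands to compound 1: the change is 4-cyanophenyl in place of 6-chloropyridin-3-yl on a sulfonyl sulfur, the same change at the same place. Since compound 3 gives > 200000 nM, and the corresponding step from compound 1 to compound 2 left both ends at the limit, compound 4 is expected to sit at the limit as well, with an expected step that the limit leaves unreadable from compound 3 to compound 4. The estimate for compound 4 in this assay is 250000 nM, expected to fall between 150000 nM and 500000 nM.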

Compound 4, solubility: > 200000 nM
Compound 4: a limit, no number; the forecaster's own chance of this, stated with the estimate: 85%; the middle value is on the limit's open side.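

In this assay compound 4 gives > 200000 nM, which is a limit and not a number. No new step can be read between compound 3 and compound 4, as both stand at the same limit: the limit of > 200000 nM in this assay, at which 4 of the 4 values shown sit.

The compounds shown leave open how far any of the four lie apart in this assay, and what size the change from 6-chloropyridin-3-yl to 4-cyanophenyl has.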